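This account rests on a few compounds, and the source may have more. Where it says the series, first, only, none or still open, it means among the compounds named here.

Measured in an assay (Rattus norvegicus) for inhibition of Fatty-acid amide hydrolase 1 (Homo sapiens); on this read-out lower numbers stand for stronger inhibition and higher numbers for weaker inhibition:
compound 1 `COC(=O)c1ccccc1-c1cnc(C(=O)CCCCCCc2ccccc2)o1`: 60 nM
compound 2 `NS(=O)(=O)c1ccccc1-c1cnc(C(=O)CCCCCCc2ccccc2)o1`: 1500 nM
compound 3 `N#Cc1ccccc1-c1cnc(C(=O)CCCCCCc2ccccc2)o1`: 130 nM

Compound 3 stands second highest of the three numbers in this assay: compound 1 is the nearer, a 2.2-fold higher number from compound 1 to compound 3 (0.34 log units; beyond the scatter), and compound 2 the farthest, a 12-fold lower number from compound 2 to compound 3 (1.06 log units; beyond the scatter). Compound 4 `Nc1ccc(-c2cnc(C(=O)CCCCCCc3ccccc3)o2)cc1` differs from compound 3 by 4-aminophenyl in place of 2-cyanophenyl on an aromatic carbon. For the measured compounds named here, no measured step swaps this same pair of groups. The nearest guides are a 25-fold higher number from compound 1 to compound 2 (1.40 log units; beyond the scatter), a large rise when a group with a hydrogen-bond donor entered, and a 12-fold lower number from compound 2 to compound 3 (1.06 log units; beyond the scatter), a large fall when that group left. Compound 4, which gains a hydrogen-bond donor, is therefore expected to give a modestly higher number, a 3.1-fold higher number from compound 3 to compound 4 (0.49 log units; beyond the scatter), estimated at 400 nM within 100 nM to 2000 nM.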

Compound 4, inhibition constant: 90 nM
The estimate for compound 4 lay 4.4-fold (0.65 log units) above the measured number; measured number below the stated range.
By their numbers in this assay, from the lowest: compounds 1, 4 and 3 (each within the scatter of the next, the first and the last beyond it); then compound 2.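

In this assay, the swap to 4-aminophenyl from 2-cyanophenyl, on the aromatic carbon next to the ring oxygen, gives a 1.4-fold lower number from compound 3 to compound 4 (0.16 log units; within the scatter), so this change leaves the number unresolved. A hydrogen-bond donor enters here without a large step, whereas sulfamoyl in compound 2 gave a 25-fold higher number from compound 1 to compound 2 (1.40 log units; beyond the scatter), so donor count alone does not track the read-out across these two changes. Nothing available bears on the cause of this result.

As far as these compounds go, since the swap changes both the group and its ring position, the contribution of each remains open. 2-Aminophenyl and 4-cyanophenyl would separate the two.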